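Fluoro in place of methyl on compound 3

A few compounds are considered here, and "the series" means these few. Any claim that something is new, unique, unknown or untested is made for them only; others in the source may bear on it.

Three compounds have values in a physicochemical assay for lipophilicity, at pH 7.4 (on this read-out lower numbers stand for lower lipophilicity and higher numbers for higher lipophilicity), so far. Compound 1 `CCCCCCCc1c(C)nc2ccccc2c1O` reads 3.39 and compound 2 `CCCCCC/C=C\Cc1c(C)[nH]c2ccccc2c1=O` reads 5.94 on this scale. Compound 3 `Cc1ccc2[nH]c(C)c(Br)c(=O)c2c1` reads 1.07 as the lowest of the three, and its distance from each of the other two lies well beyond the usual scatter of repeated measurements.

The next compound to be measured, compound 4 `Cc1[nH]c2ccc(F)cc2c(=O)c1Br`, departs from compound 3 in one place. The change fluoro in place of methyl on an aromatic carbon is fluoro in place of methyl on an aromatic carbon of a six-membered aromatic ring of carbon only, part of a fused or bridged system of two rings. Among the measured compounds shown here, no two measured compounds differ in only one place, so the data hold no direct precedent for this swap. The expectation therefore rests on compound 3 at 1.07 as the starting point and on the modest size of the structural change. The step expected in this assay is a number 0.27 log units lower from compound 3 to compound 4 (within the scatter) and so a small one toward lower numbers, not beyond the scatter. Compound 4 is estimated at 0.8 with an expected range from 0.35 to 1.25 on this scale.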

Compound 4, distribution coefficient: 1.61
Compound 4: the middle estimate sits 0.81 log units below what was measured; the whole stated range lies below it.
By their numbers in this assay, from the lowest: compound 3; then compound 4; then compound 1; then compound 2.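

In this assay, compound 3 and compound 4 give the first reading of a single change among the compounds shown: fluoro in place of methyl on an aromatic carbon, meta to a fused ring and para to a fused ring, goes with a number 0.54 log units higher from compound 3 to compound 4 (beyond the scatter) in this pair. Among the compounds shown here, no two of the earlier compounds differed in only one place, so their spread could not isolate any one group, whereas here everything outside this swap stays the same and the number rises, with the step standing clear of the usual scatter. Nothing in the available data accounts for the direction or the size of this step.

On these data alone, this single pair covers one position on one core, so it remains open whether a chloro or an amine in the same place would move the number in the same direction, or whether fluoro on another aromatic carbon of that ring would give a step of similar size. As far as these compounds go, it also remains open whether the swap would behave the same way on a core carrying a longer chain, like those of compound 1 and compound 2, in place of the bromo.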